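Fluoro for Hydrogen on the Aromatic Ring of Compound 1

The compounds below may be only part of what the source reports. "The series", "measured", "known", "first", "only" and "open" are said of these compounds alone.

Compound 1 `CNc1nc(NCc2ccc(NC(C)=O)cc2)cc(-c2ccccn2)n1`: 2 nM
Compound 2 `CNc1nc(NCc2ccc(NS(C)(=O)=O)cc2)cc(-c2ccccn2)n1`: 3 nM

Of the compounds shown here, two have so far been measured in a functional assay on HEK293 cells for agonist activity at protein Gpr39 (Rattus norvegicus), read by inositol phosphate accumulation; on this read-out higher numbers stand for an effect only at larger amounts of compound and lower numbers for an effect already at smaller amounts. Compound 1 gives the lower of the two numbers with 2 nM, while compound 2 gives 3 nM; the two values lie within the scatter of each other, so neither compound can be called the more potent. Going by the values given here, the single measured step, a 1.5-fold higher number from compound 1 to compound 2 (0.18 log units; within the scatter), comes from putting methylsulfonyl in place of acetyl on a nitrogen on an aromatic ring, and it leaves the read-out essentially unchanged.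

Compound 3 `CNc1nc(NCc2ccc(NC(C)=O)cc2F)cc(-c2ccccn2)n1` differs from compound 1 in one place: fluoro in place of hydrogen on an aromatic carbon. Among the compounds with values here, no measured step concerns this exchange. Within the data shown here, the one step in hand alters the acetyl group itself and says nothing about adding a fluorine to the ring that carries the acetamido group. With no direction indicated by the data, a step of a 1.3-fold higher number from compound 1 to compound 3 (0.10 log units; within the scatter) is expected, that is, nothing beyond the scatter. Compound 3 is therefore estimated at 2.5 nM, with a range from 1 nM to 8 nM.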

Compound 3, half-maximal effective concentration: 0.6 nM
Beside the measured number, compound 3's estimate is 4.2-fold (0.62 log units) above it; the whole stated range lies above it.
By their numbers in this assay, from the lowest: compound 3; then compounds 1 and 2 (each within the scatter of the next).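

In this assay the exchange of hydrogen for fluoro on an aromatic carbon, ortho to a large group and meta to an acetamido group, gives a 3.3-fold lower number from compound 1 to compound 3 (0.52 log units; beyond the scatter) and so moves the read-out towards an effect at smaller amounts of compound. The earlier step, a 1.5-fold higher number from compound 1 to compound 2 (0.18 log units; within the scatter), changed the group on the nitrogen and stayed within the scatter, whereas this one goes beyond it, so this ring carbon is a place where adding a single fluorine atom registers in the read-out. No measurement among these compounds accounts for the shift, and its cause remains unknown.

On these data alone, whether a chlorine atom, a methyl group or a methoxy group on the same carbon would shift the number as fluoro does remains open, as does the outcome of fluoro on the other carbons of this ring. As far as these compounds go, it is equally open whether fluoro on this carbon would produce a similar step in compound 2, which carries methylsulfonyl in place of acetyl.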